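Swapping a Methyl for a Dimethylcarbamoyl on the Aryl Ring

The source may hold more compounds than are shown below. What is called first, only, known or untested is meant among the compounds shown, and "the series" means these compounds.

Three close relatives of one core have been examined in an assay on isolated protein for inhibition of cyclin-dependent kinase 2-associated protein 1 (Homo sapiens); a lower number here means a stronger inhibitor, a higher number a weaker inhibitor. Compound 3 `Cc1ccc(-c2cc(C(=O)N[C@H]3CCCNC3)c(NC(N)=O)s2)cc1` gives 5500 nM. Compound 1 `CN(C)c1ccc(-c2cc(C(=O)N[C@H]3CCCNC3)c(NC(N)=O)s2)cc1` carries a dimethylamino group where compound 3 carries a methyl. Compound 1 gives 8400 nM, and the step of a 1.5-fold lower number from compound 1 to compound 3 (0.18 log units; within the scatter) is within the scatter, so the two compounds cannot be ranked against each other. Compound 2 `NC(=O)Nc1sc(-c2ccc(C(=O)N3CCOCC3)cc2)cc1C(=O)N[C@H]1CCCNC1`, which bears a morpholine amide at the same position, has a result of "not determined" (no result reported), so it offers no number.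

Compound 4 `CN(C)C(=O)c1ccc(-c2cc(C(=O)N[C@H]3CCCNC3)c(NC(N)=O)s2)cc1` differs from compound 3 by dimethylcarbamoyl in place of methyl on an aromatic carbon, at a position para to a large group. Among the measured compounds shown here, no measured step involves a dimethylcarbamoyl group, and the one measured step at this position, from a dimethylamino to a methyl, stayed within the scatter. On that basis a step of a 1.1-fold higher number from compound 3 to compound 4 (0.04 log units; within the scatter) of no size beyond the scatter is expected. Compound 4 is therefore estimated at 6000 nM, with a range from 2000 nM to 18000 nM.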

Compound 4, half-maximal inhibitory concentration: 3700 nM
Compound 4: middle estimate off by 1.6-fold (0.21 log units), on the high side; the measured number falls inside the stated range.
By their numbers in this assay, from the lowest: compounds 4, 3 and 1 (each within the scatter of the next, the first and the last beyond it).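

This position takes a much larger group without a clear penalty: dimethylcarbamoyl brings five heavy atoms and a hydrogen-bond acceptor in place of the single carbon of methyl, yet a 1.5-fold lower number from compound 3 to compound 4 (0.17 log units; within the scatter) in this assay. Set against dimethylamino, the same group gives the only step at this position that clears the scatter, a 2.3-fold lower number from compound 1 to compound 4 (0.36 log units; beyond the scatter), although compound 3 lies within the scatter of both compound 1 and compound 4, so the three compounds form no clean ladder. Nothing shown gives a reason for that modest step.

From the compounds shown here alone, with no number for compound 2, it remains open whether a morpholine amide fares like the dimethylcarbamoyl of compound 4. Going by these compounds, how a carboxylic acid or a primary amine at this position would read in this assay also remains unknown.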